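This account rests on a few compounds, and the source may have more. Where it says the series, first, only, none or still open, it means among the compounds named here.

Measured so far in a functional assay on A549 cells (Homo sapiens) for inhibition, read by MTT assay, with a stated time of 72 h; a lower number here means a stronger inhibitor, a higher number a weaker inhibitor:
compound 1 `CNc1nc(C(F)(F)F)c(C(=O)N/N=C/c2cccc(C(F)(F)F)c2)s1` gives > 100 ug/mL.
compound 2 `CN(C(=O)NC(=O)c1ccccc1F)c1nc(C(F)(F)F)c(C(=O)N/N=C/c2cccc(C(F)(F)F)c2)s1` gives 19.5 ug/mL.
compound 3 `CN(C(=O)NC(=O)c1ccccc1F)c1nc(C(F)(F)F)c(C(=O)N/N=C/c2ccc(C(F)(F)F)cc2)s1` gives 5.68 ug/mL.

The entry of compound 1 is a limit of the assay, not a number; it sits at the limit of > 100 ug/mL in this assay, at which 1 of the 3 values shown sits. Compound 2 and compound 3 carry the same atoms joined differently, the difference being (4-(trifluoromethyl)phenyl in place of 3-(trifluoromethyl)phenyl on a carbon with a double bond to nitrogen), and this change gave a 3.4-fold lower number from compound 2 to compound 3 (0.54 log units; beyond the scatter). Among the two numbers, compound 3 stands lower, with compound 2 nearest. Compound 1 is reached from compound 2 by one change, (hydrogen in place of ((2-fluorophenyl)carbonyl)carbamoyl on a nitrogen on an aromatic ring), which gave an at least 5.1-fold higher number from compound 2 to compound 1 (0.70 log units; beyond the scatter), the outcome being the limit.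

Compound 4 `CNc1nc(C(F)(F)F)c(C(=O)N/N=C/c2ccc(C(F)(F)F)cc2)s1` has not yet been measured in this assay. It differs from compound 3 by hydrogen in place of ((2-fluorophenyl)carbonyl)carbamoyl on a nitrogen on an aromatic ring, the same change as that between compound 2 and compound 1, at a place described in identical words. A weakening of at least comparable size is expected, an 11-fold higher number from compound 3 to compound 4 (1.02 log units; beyond the scatter), because the earlier instance gave an at least 5.1-fold higher number from compound 2 to compound 1 (0.70 log units; beyond the scatter), though a single prior step leaves the size uncertain. For compound 4 the expected result in this assay is 60 ug/mL, with a likely range from 20 ug/mL to 200 ug/mL, and a real chance that only a limit is reported.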

Compound 4, half-maximal inhibitory concentration: > 100 ug/mL
Compound 4: a limit, no number; the forecaster's own chance of this, stated with the estimate: 45%; at least 1.6-fold (0.22 log units) between middle value and limit.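

In this assay, hydrogen in place of ((2-fluorophenyl)carbonyl)carbamoyl on a nitrogen on an aromatic ring gave an at least 17-fold higher number from compound 3 to compound 4 (1.24 log units; beyond the scatter), so the direction of this change held on both the 3-(trifluoromethyl)phenyl and the 4-(trifluoromethyl)phenyl compounds. The entry of compound 4, > 100 ug/mL, is a limit of the assay and not a number. The direction therefore carries from one core to the other, but the size of the change does not, as far as these compounds can tell: the same change on two cores in this assay, an at least 5.1-fold higher number (0.70 log units; beyond the scatter) from compound 2 to compound 1 and an at least 17-fold higher number (1.24 log units; beyond the scatter) from compound 3 to compound 4; the limit leaves it open whether they differ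

The compounds shown leave open how much of the ((2-fluorophenyl)carbonyl)carbamoyl group is needed on that nitrogen, for instance whether an acetyl, a plain carbamoyl or a benzoylcarbamoyl without the fluorine would keep the numbers near those of compound 2 and compound 3. Also open, as far as these compounds go, is whether the same change behaves alike with a different group on the carbon with a double bond to nitrogen, such as 4-methoxyphenyl or a pyridine ring.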